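Trading a sulfamoyl for a difluoromethoxy on the aryl ring

A few compounds are considered here, and "the series" means these few. Any claim that something is new, unique, unknown or untested is made for them only; others in the source may bear on it.

Measured compounds:
Compound 1, `CCSC(=S)SCC(=O)c1ccc(S(N)(=O)=O)cc1`: 20000 nM
Compound 2, `CSC(=S)SCC(=O)c1ccc(Cl)c(Cl)c1`: 6310 nM
Compound 3, `COc1ccc(C(=O)CSC(C)=O)cc1`: 25100 nM

Of the compounds shown here, three have been tested in a functional assay on HeLa cells (Homo sapiens) for antiproliferative activity, read by resazurin assay; a lower number here means a stronger inhibitor, a higher number a weaker inhibitor. Compound 1 gives 20000 nM, the second highest of the three numbers. Its nearest neighbour is compound 3, whose value of 25100 nM lies within the usual scatter of compound 1, so the two cannot be told apart. For the measured compounds named here, compound 2, at 6310 nM, is the one value that stands clearly apart, beyond the scatter and on the lower side.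

Compound 4, `CCSC(=S)SCC(=O)c1ccc(OC(F)F)cc1`, has not yet been measured. It differs from compound 1 in one place: difluoromethoxy in place of sulfamoyl on an aromatic carbon. Going by the values given here, no pair of measured compounds shows this change, so no measured step tells how large its effect should be. Given that compound 2 sits at 6310 nM with different substituents on the same position of the ring, a small shift in the expected step of a 1.8-fold lower number from compound 1 to compound 4 (0.26 log units; within the scatter) toward a lower number seems plausible, though it may well stay inside the scatter. Compound 4 is expected to give about 11000 nM, most likely between 3500 nM and 35000 nM.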

Compound 4, half-maximal inhibitory concentration: 3980 nM
Beside the measured number, compound 4's estimate is 2.8-fold (0.44 log units) above it, within the range that was stated.
By their numbers in this assay, from the lowest: compounds 4 and 2 (each within the scatter of the next); then compounds 1 and 3 (each within the scatter of the next).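

In this assay, for the compounds shown here, replacing the sulfamoyl on the aromatic carbon with difluoromethoxy gives a 5.0-fold lower number from compound 1 to compound 4 (0.70 log units; beyond the scatter), the only step so far between compounds that differ in one place. With the rest of compound 1 unchanged, this shows that the group at this position can shift the number, even though both groups have 4 heavy atoms and neither contains a ring. No measurement bearing on this step is available, so the reason for the shift remains unknown.

This single step cannot show whether the lower number comes from losing the sulfamoyl or from gaining the difluoromethoxy. The compounds shown also leave open how a methoxy, a trifluoromethoxy or a carboxylic acid would behave at the same position on the core of compound 1.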